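Methyl on the amide nitrogen: compound 1 to compound 4

The source may report more compounds than this note shows. Statements on the series, on what has been measured and on what is new or still open speak of the compounds shown alone.

Measured so far:
compound 1 `NC(=O)/C=C/c1ccncc1-c1ccc2ccccc2c1` — 102%
compound 2 `COC1CN(C(=O)/C=C/c2ccncc2-c2ccc3[nH]ncc3c2)C1` — 98%
compound 3 `Cn1ncc2cc(-c3cnccc3/C=C/C(=O)N3CCOCC3)ccc21` — 95%

In an assay on a protein complex for inhibition of CDK8/Cyclin C (Homo sapiens), with a stated time of 1 h, tested at 10 uM (a lower number here means less inhibition, a higher number more inhibition at the concentration tested (going by the name of the read-out)), compound 1 gives 102%, compound 2 gives 98% and compound 3 gives 95%. Compound 1 nominally carries the top number of the three, but its gaps to compound 2 and to compound 3 both lie within the scatter, so the three compounds are not separated by these readings; the three numbers are level with one another. Among the measured compounds shown here, no pair of measured compounds differs in a single place, so no measured step is available.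

For the measured compounds named here, compound 4 `CNC(=O)/C=C/c1ccncc1-c1ccc2ccccc2c1` is the one untested member. Against compound 1 the change is methyl in place of hydrogen on an amide-type nitrogen. The other parts of the molecule are unchanged. On these data alone, with compound 1 reading at the ceiling of the assay, a step beyond the scatter is not expected; if anything, a small downward drift is the only direction that remains open, and it is expected to stay within the scatter, so the step of a number 6 percentage points lower from compound 1 to compound 4 (within the scatter) is estimated as essentially flat. Compound 4 is therefore expected to give 96%, with a range from 82% to 105%.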

Compound 4, a percentage reported as inhibition, at one concentration (the size of the read-out at that concentration, not a potency): 101%
The estimate for compound 4 lay 5 percentage points below the measured number, within the range that was stated.
By their numbers in this assay, from the lowest: compounds 3, 2, 4 and 1 (each within the scatter of the next).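

In this assay, methyl in place of hydrogen on the amide-type nitrogen gives a number 1 percentage points lower from compound 1 to compound 4 (within the scatter), the only step shown that changes one place in the series. The amide hydrogen of compound 1 can therefore be exchanged for methyl without a separable change in this read-out, and the carbamoyl to methylcarbamoyl change leaves the reading level at a single tested concentration. No measurement shown explains the size of this step.

On these data alone, a longer chain such as ethyl on the same nitrogen, a chain ending in an amine, or a carboxylic acid in place of the carbamoyl group remains open, as does whether any of these would bring a step beyond the scatter. As far as these compounds go, with compound 1 at 102% and compound 4 at 101%, both being readings at one concentration rather than potencies, any difference between these two compounds that a lower tested concentration or a full concentration series might reveal also remains open.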